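The source may hold more compounds than are shown below. What is called first, only, known or untested is meant among the compounds shown, and "the series" means these compounds.

Measured compounds:
compound 1, `O=S(=O)(/C=C/c1ccc(F)cc1F)Cc1ccc(Nc2ncnc3ccccc23)cc1` — 69000 nM
compound 2, `O=S(=O)(/C=C/c1ccc(Cl)cc1Cl)Cc1ccc(Nc2ncnc3cc(Cl)ccc23)cc1` — 48000 nM

Both were tested in a functional assay on SK-OV-3 cells (Homo sapiens); on this read-out higher numbers stand for weaker inhibition of growth and lower numbers for stronger inhibition of growth. Compound 2, with 48000 nM, has the smaller of the two numbers, but its gap to compound 1, at 69000 nM, lies within the usual scatter, so the two compounds cannot be told apart on these data. Compound 3, `O=S(=O)(/C=C/c1ccc(F)cc1F)Cc1ccc(Nc2ncnc3cc(Cl)ccc23)cc1`, has not yet been measured in this assay. It differs from compound 2 in one place: 2,4-difluorophenyl in place of 2,4-dichlorophenyl on a double-bonded chain carbon bound to a double-bonded chain carbon. For the measured compounds named here, no measured pair isolates this change, so nothing in the data fixes its size or direction. Compound 1 carries the same 2,4-difluorophenyl group and gives 69000 nM, close to compound 2. Compound 3 is therefore expected to land near both, with a step of a 1.3-fold higher number from compound 2 to compound 3 (0.11 log units; within the scatter) that stays within the scatter. The estimate for compound 3 in this assay is 62000 nM, with a range from 25000 nM to 160000 nM.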

Compound 3, concentration for 50% growth inhibition: > 100000 nM
Compound 3 ended at the assay's limit; the forecaster's own chance of this, stated with the estimate: 15%; middle value at least 1.6-fold (0.20 log units) away from the limit.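

In this assay, putting 2,4-difluorophenyl in place of 2,4-dichlorophenyl on a double-bonded chain carbon bound to a double-bonded chain carbon now has a direction, with an at least 2.0-fold higher number from compound 2 to compound 3 (0.31 log units; beyond the scatter), so at this position the change weakens inhibition of growth beyond the scatter. Chloro in place of hydrogen on an aromatic carbon gives an at least 1.4-fold higher number from compound 1 to compound 3 (0.16 log units; that floor lies within the scatter), so that change cannot be told from no change on these data, although its true size could be larger. Both steps are floors and not sizes, since compound 3 stands at a limit of the assay and has no exact number: the limit of > 100000 nM in this assay, at which 1 of the 3 values shown sits.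

As far as these compounds go, how far compound 3 lies past that limit remains open, and with it the true size of both steps. From the compounds shown here alone, it is also open whether a plain phenyl or a pyridyl at this place would keep the growth inhibition of compound 2 or lose it.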